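Swapping a nitrile for trifluoromethoxy in a cytotoxicity test

A few compounds are considered here, and "the series" means these few. Any claim that something is new, unique, unknown or untested is made for them only; others in the source may bear on it.

Measured in a functional assay on Jurkat cells (Homo sapiens) for cytotoxicity, read by luminescence and CellTiter-Glo, with a stated time of 3 days; a higher number here means a weaker inhibitor, a lower number a stronger inhibitor:
- Compound 1 `N#Cc1cccc(NC(=O)c2cc(F)ccc2O)c1`: "not determined" (no result reported)
- Compound 2 `O=C(Nc1ccc(OC(F)(F)F)c(Cl)c1)c1cc(F)ccc1O`: 700 nM

Compound 1 has no single number here, so it offers no starting value. Compound 3 `O=C(Nc1cccc(OC(F)(F)F)c1)c1cc(F)ccc1O` is built from it by one change, trifluoromethoxy in place of cyano on an aromatic carbon. The size of this step in this assay cannot be stated without a number for compound 1. Going by the values given here, the only guide is compound 2 at 700 nM, and a result in that region or somewhat weaker is expected. For compound 3 the estimated value is 2000 nM, with an expected range of 600 nM to 8000 nM.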

Compound 3, half-maximal inhibitory concentration: 700 nM
The estimate for compound 3 lay 2.9-fold (0.46 log units) above the measured number; the measured number falls inside the stated range.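

Going by these compounds alone, compound 1 has no number in this assay, so no step from compound 1 to compound 3 can be read. The compounds shown leave open how far trifluoromethoxy in place of cyano shifts the value, and nothing available here bears on the result.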